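The compounds below may be only part of what the source reports. "The series", "measured", "known", "first", "only" and "open" are said of these compounds alone.

In a functional assay on KB cells (Homo sapiens) for antiproliferative activity, read by sulforhodamine B assay, with a stated time of 3 days (on this read-out lower numbers stand for an effect already at smaller amounts and higher numbers for an effect only at larger amounts of compound), compound 1 `CCC1=C(O)c2c(oc(-c3ccc(CC)cc3)cc2=O)C(CC)(CC)C1=O` gives 21.9 uM, compound 2 `CCC1=C(O)c2c(oc(-c3ccc(F)cc3)cc2=O)C(CC)(CC)C1=O` gives 33 uM, and compound 3 `CCC1=C(O)c2c(oc(-c3ccc(OC)c(F)c3)cc2=O)C(CC)(CC)C1=O` gives 26.7 uM. These three values lie within the usual scatter of one another, so compound 3 is not set apart from the other two. Compound 4 `CCC1=C(O)c2c(oc(-c3ccc(OC)c(Cl)c3)cc2=O)C(CC)(CC)C1=O` differs from compound 3 by one swap: chloro in place of fluoro on an aromatic carbon. Among the measured compounds shown here, no measured pair makes this exact swap. The closest evidence comes from other swaps on the same aromatic ring: a 1.2-fold higher number from compound 1 to compound 3 (0.09 log units; within the scatter), a 1.2-fold lower number from compound 2 to compound 3 (0.09 log units; within the scatter) and a 1.5-fold higher number from compound 1 to compound 2 (0.18 log units; within the scatter), all small. No shift beyond the scatter is therefore expected in this assay. The expected size of the step is a 1.1-fold lower number from compound 3 to compound 4 (0.05 log units; within the scatter). For compound 4 the estimated value is 24 uM, with an expected range of 13 uM to 43 uM.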

Compound 4, concentration for half-maximal effect: 24.9 uM
Compound 4: middle estimate off by 1.0-fold (0.02 log units), on the low side, and the stated range covers the measured number.
By their numbers in this assay, from the lowest: compounds 1, 4, 3 and 2 (each within the scatter of the next).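

In this assay, among the compounds shown here, chloro in place of fluoro, ortho to a methoxy group, gives the first direct reading of this swap, with a 1.1-fold lower number from compound 3 to compound 4 (0.03 log units; within the scatter) as its result. The comparisons with the other aryl groups also stay small, with a 1.3-fold lower number from compound 2 to compound 4 (0.12 log units; within the scatter) and a 1.1-fold higher number from compound 1 to compound 4 (0.06 log units; within the scatter) as the printed steps. No measurement here offers an explanation for these small steps. Going by these compounds, it remains open whether an amine or a carboxylic acid at this ring carbon would move the number beyond the scatter. The same question stands for longer chains in place of the ethyl groups on the shared core.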